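The source may report more compounds than this note shows. Statements on the series, on what has been measured and on what is new or still open speak of the compounds shown alone.

Of the compounds shown here, three have so far been tested in a functional assay on HepG2 cells (Homo sapiens) for inhibition, read by MTT assay, with a stated time of 72 h; on this read-out higher numbers stand for weaker inhibition and lower numbers for stronger inhibition. Compound 2 `CN(C(=O)NC(=O)c1cccc([N+](=O)[O-])c1)c1nc(C(F)(F)F)c(C(=O)N/N=C/c2ccccc2C(F)(F)F)s1` gives 4.8 ug/mL in this assay. Compound 1 `CN(C(=O)NC(=O)c1ccc(F)c(F)c1)c1nc(C(F)(F)F)c(C(=O)N/N=C/c2ccc([N+](=O)[O-])cc2)s1` gives 6.23 ug/mL in this assay, and the gap between these two numbers lies within the usual scatter, so neither can be called the stronger. Compound 3 `CNc1nc(C)c(C(=O)N/N=C/c2cc(C(F)(F)F)cc(C(F)(F)F)c2)s1` reaches only the limit of > 100 ug/mL in this assay, not a number; one of the three values thus sits at the limit of > 100 ug/mL in this assay, at which 1 of the 3 values shown sits.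

Compound 4 `CN(C(=O)NC(=O)c1ccc(C(F)(F)F)cc1)c1nc(C(F)(F)F)c(C(=O)N/N=C/c2ccccc2C(F)(F)F)s1` differs from compound 2 in one place: 4-(trifluoromethyl)phenyl in place of 3-nitrophenyl on a carbonyl carbon. Within the data shown here, no pair of measured compounds differs in a single place, so no measured step shows how such a change acts. The step of a 1.1-fold higher number from compound 2 to compound 4 (0.06 log units; within the scatter) is therefore expected to stay within the scatter, with no clear direction. Compound 4 is expected to give about 5.5 ug/mL in this assay, between 2 ug/mL and 15 ug/mL.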

Compound 4, half-maximal inhibitory concentration: 3.64 ug/mL
Estimate against measurement, compound 4: 1.5-fold (0.18 log units) above, within the range that was stated.
By their numbers in this assay, from the lowest: compounds 4, 2 and 1 (each within the scatter of the next). At a limit, above all of these: compound 3.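

Putting 4-(trifluoromethyl)phenyl in place of 3-nitrophenyl on this carbonyl carbon gives, in this assay, a 1.3-fold lower number from compound 2 to compound 4 (0.12 log units; within the scatter). Among these compounds, this is the first measured single change at this position, and the two groups cannot be told apart by this read-out, although they share little beyond the aromatic ring. Nothing measured here explains this result.

This is one pair, so it cannot show whether the position tolerates change in general. A carboxylic acid, an amine or a short alkyl chain on this carbonyl carbon remains untested in the compounds shown.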